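Replacing methyl with fluoro in compound 3

The compounds below may be only part of what the source reports. "The series", "measured", "known", "first", "only" and "open" are said of these compounds alone.

In a functional assay on MM1.S cells (Homo sapiens) for cytotoxicity, read by MTT assay, with a stated time of 48 h (a lower number here means a stronger inhibitor, a higher number a weaker inhibitor), compound 1 (`C#CC(C)(C)OC(=O)NN=C1C(Cl)=C(Cl)C(Cl)=C1Cl`) has no usable result, its entry reading "not determined" (no result reported) in the record. Compound 2 (`FC(F)(F)c1cccc(NN=C2C(Cl)=C(Cl)C(Cl)=C2Cl)c1`) gives 1000 nM as its measured value. Compound 3 (`Cc1cccc(NN=C2C(Cl)=C(Cl)C(Cl)=C2Cl)c1`) gives > 3000 nM as its reading, and this is a limit and not a number. Compound 4 (`Fc1cccc(NN=C2C(Cl)=C(Cl)C(Cl)=C2Cl)c1`) keeps the shared core of compound 3 and changes a single group, with fluoro in place of methyl on an aromatic carbon. Among the measured compounds shown here, the only measured step that bears on this is an at least 3.0-fold higher number from compound 2 to compound 3 (0.47 log units; beyond the scatter) when methyl replaced trifluoromethyl, and it suggests that removing methyl could lower the number. Fluoro is a different group from trifluoromethyl, so only a small move in that direction is expected, and the result may stay close to the limit. The estimated change is an at least 1.2-fold lower number from compound 3 to compound 4 (0.07 log units; that floor lies within the scatter) in this case. For compound 4 the estimate is 2500 nM with an expected range from 900 nM to 6000 nM overall.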

Compound 4, half-maximal inhibitory concentration: 1500 nM
For compound 4 the middle estimate is 1.7-fold (0.22 log units) above the measured one, within the range that was stated.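

Fluoro and trifluoromethyl on this aromatic carbon cannot be told apart, with a 1.5-fold higher number from compound 2 to compound 4 (0.18 log units; within the scatter). Going from methyl to fluoro gives an at least 2.0-fold lower number from compound 3 to compound 4 (0.30 log units; that floor lies within the scatter), which points the same way as the earlier step from trifluoromethyl to methyl read in reverse, although this floor does not clear the scatter as that step did. The true size of the step from methyl to fluoro cannot be read, because compound 3 holds a limit and not a number: the limit of > 3000 nM in this assay, at which 1 of the 4 values shown sits.

The compounds shown leave open whether a group of another kind on this carbon, such as an amine, a carboxylic acid or a longer alkyl chain, would bring the number lower than fluoro and trifluoromethyl do. Compound 1, with no usable result, adds nothing to this comparison.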